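Swapping a methoxyphenyl for a bromophenyl on the core

This account rests on a few compounds, and the source may have more. Where it says the series, first, only, none or still open, it means among the compounds named here.

Measured so far:
compound 1 `COc1ccc(-n2cc(COC(=O)c3cc4ccccc4[nH]3)nn2)cc1` gives 42500 nM
compound 2 `O=C(OCc1cn(-c2ccccc2Br)nn1)c1cc2ccccc2n1Cc1cn(-c2ccccc2Br)nn1` gives 12100 nM
compound 3 `Cc1cc(C)cc(-n2cc(COC(=O)c3cc4ccccc4n3Cc3cn(-c4cc(C)cc(C)c4)nn3)nn2)c1` gives 50200 nM

In an ADME assay on HEK293 cells (Homo sapiens) for cytotoxicity, read by MTT assay, with a stated time of 48 h (a higher number here means a weaker inhibitor, a lower number a stronger inhibitor), compound 1 stands second highest of the three numbers. Compound 3 sits within the scatter of it, so no order between them can be read. Compound 2 lies beyond the scatter, with the lower number, and it carries 2-bromophenyl groups on a core that also bears a second substituent.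

Compound 4 `O=C(OCc1cn(-c2ccccc2Br)nn1)c1cc2ccccc2[nH]1` is the unmeasured partner of compound 1. It differs in one place: 2-bromophenyl in place of 4-methoxyphenyl on an aromatic nitrogen. Going by the values given here, no measured pair shows this change on its own, so the size of the step is uncertain. A small shift toward a lower number is expected, a 1.7-fold lower number from compound 1 to compound 4 (0.23 log units; within the scatter), because compound 2 gives 12100 nM with the same entering group. Compound 4 is therefore estimated at 25000 nM, within 10000 nM to 60000 nM.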

Compound 4, half-maximal inhibitory concentration: > 200000 nM
Compound 4 was reported as a limit (the forecaster's own chance of this, stated with the estimate: 10%); middle value at least 8.0-fold (0.90 log units) from the limit.
By their numbers in this assay, from the lowest: compound 2; then compounds 1 and 3 (each within the scatter of the next). At a limit, above all of these: compound 4.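

In this assay compound 4 gives > 200000 nM, which is a limit of the assay and not a number. Going by these compounds alone, with 2-bromophenyl in place of 4-methoxyphenyl on the aromatic nitrogen, the single change gives an at least 4.7-fold higher number from compound 1 to compound 4 (0.67 log units; beyond the scatter), so this position clearly affects the result, and the higher number means a weaker inhibitor. The limit leaves the full size of the step unknown.

This one pair cannot separate losing the methoxy group from gaining the bromine. The compounds shown also leave open how a phenyl ring carrying an amine or a carboxylic acid would read here.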